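The source may hold more compounds than are shown below. What is called first, only, known or untested is meant among the compounds shown, and "the series" means these compounds.

In an ADME assay on L6 cells (Rattus norvegicus) for cytotoxicity, read by resazurin assay, with a stated time of 72 h (a higher number here means that more compound is needed for the effect, a lower number that less compound is needed), compound 1 (`O=C(NCCCO)C(c1ccccc1)c1ccccc1`) gives 18000 nM while compound 2 (`O=C(c1ccccc1)n1c(=O)ccn(CCCNC(=O)C(c2ccccc2)(c2ccccc2)c2ccccc2)c1=O`) gives 9000 nM and these two numbers lie within the usual scatter of each other. Compound 3 (`O=C(NCCCO)C(c1ccccc1)(c1ccccc1)c1ccccc1`) keeps the rest of compound 1 but carries phenyl in place of hydrogen on a saturated chain carbon bound to two aromatic carbons and a carbonyl carbon. Within the data shown here, no pair of measured compounds shows this change alone, so the data give no direct size for the step. Compound 2 also has phenyl at that carbon and gives 9000 nM in this assay despite its very different remainder, which is only a weak hint. A small move toward a lower number, not beyond the scatter, is expected, and the estimated change is a 1.5-fold lower number from compound 1 to compound 3 (0.18 log units; within the scatter) in this comparison. For compound 3 the estimated value is 12000 nM with an expected range from 5000 nM to 30000 nM in repeated measurements.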

Compound 3, half-maximal effective concentration: 19000 nM
Beside the measured number, compound 3's estimate is 1.6-fold (0.20 log units) below it; the measured number falls inside the stated range.
By their numbers in this assay, from the lowest: compounds 2, 1 and 3 (each within the scatter of the next, the first and the last beyond it).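

In this assay, phenyl in place of hydrogen on a saturated chain carbon bound to two aromatic carbons and a carbonyl carbon gives a 1.1-fold higher number from compound 1 to compound 3 (0.02 log units; within the scatter). Among these compounds, this is the first direct reading of the change, and it shows that adding one six-membered aromatic ring of carbon only at this position leaves the cell reading unchanged within the usual scatter. No measurement shown here offers an explanation for this result.

The compounds shown leave open whether a different group at this carbon, such as an amine or a carboxylic acid, would move the number beyond the scatter. Among the compounds shown here, it also remains open whether phenyl at this position would have the same small effect with a longer chain in place of the one carrying the hydroxyl group.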